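Compound 3: A Longer Amine Chain

This account rests on a few compounds, and the source may have more. Where it says the series, first, only, none or still open, it means among the compounds named here.

In a functional assay on A549 cells (Homo sapiens) for cytotoxicity, read by MTT assay, with a stated time of 48 h (on this read-out higher numbers stand for weaker inhibition and lower numbers for stronger inhibition), compound 1 (`CCN(CC)CCCOc1c(O)cc(O)c2c(=O)cc(-c3ccccc3)oc12`) gives > 100000 nM as its reading, which is a limit of the assay and not a number. Compound 2 (`CNCCOc1c(O)cc(O)c2c(=O)cc(-c3ccccc3)oc12`) has no single number, and its entry reads "not determined" (no result reported) in this test. Compound 3 is `CN(C)CCCOc1c(O)cc(O)c2c(=O)cc(-c3ccccc3)oc12` in structure. The change is (dimethylamino)methyl in place of methylamino on a saturated chain carbon, two bonds along the chain from an oxygen on an aromatic ring in counted terms, which also reads 2-(methylamino)ethoxy to 3-(dimethylamino)propoxy. Among the compounds with values here, compound 1 at > 100000 nM is the only guide and again a limit, so no step beyond the scatter is expected in this assay here. For compound 3 the estimated value is 100000 nM with 40000 nM to 200000 nM as the expected range.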

Compound 3, half-maximal inhibitory concentration: > 100000 nM
Compound 3 ended at the assay's limit; the forecaster's own chance of this, stated with the estimate: 55%; the middle value sits exactly at the limit.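

In this assay compound 1 and compound 3 both sit at a limit, and no step can be read between them. Going by these compounds, whether any amine chain on the shared core gives a reading short of that limit stays open.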